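Removing one methoxy from the aryl ring of compound 2

A few compounds are considered here, and "the series" means these few. Any claim that something is new, unique, unknown or untested is made for them only; others in the source may bear on it.

Measured so far in a functional assay on NCI/ADR-RES cells (Homo sapiens) for inhibition, read by sulforhodamine B assay, with a stated time of 48 h; on this read-out lower numbers stand for stronger inhibition of growth and higher numbers for weaker inhibition of growth:
compound 1 `COc1ccc(-c2cc(/C=C/C(=O)c3ccc(N)cc3)[nH]n2)cc1` gives 15500 nM
compound 2 `COc1cc(-c2cc(/C=C/C(=O)c3ccc(N)cc3)[nH]n2)cc(OC)c1OC` gives 65800 nM
compound 3 `COc1ccc(C(=O)/C=C/c2cc(-c3cc(OC)c(OC)c(OC)c3)n[nH]2)cc1` gives 9850 nM

Compound 2 stands highest of the three numbers in this assay; compound 1 sits at a lower number and compound 3 at the lowest, and compound 2 is beyond the scatter from both. For the measured compounds named here, the only single-place step in the set is a 6.7-fold lower number from compound 2 to compound 3 (0.82 log units; beyond the scatter), a change at the ketone-bearing ring rather than at the ring carrying the methoxy groups, so it does not bear on the change considered here. Compound 4 `COc1ccc(-c2cc(/C=C/C(=O)c3ccc(N)cc3)[nH]n2)cc1OC` differs from compound 2 by hydrogen in place of methoxy on an aromatic carbon. Going by the values given here, compound 1 and compound 2, which differ at the same ring by more than one group, show a lower number for compound 1 than for compound 2, but no single step connects them. On that basis a modest step toward a lower number is expected, a 2.2-fold lower number from compound 2 to compound 4 (0.34 log units; beyond the scatter), with wide uncertainty. Compound 4 is therefore estimated at 30000 nM, in the range 12000 nM to 80000 nM.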

Compound 4, concentration for total growth inhibition: > 100000 nM
Compound 4: only a limit was reported; the forecaster's own chance of this, stated with the estimate: 5%; middle value at least 3.3-fold (0.52 log units) away from the limit.
By their numbers in this assay, from the lowest: compounds 3 and 1 (each within the scatter of the next); then compound 2. At a limit, above all of these: compound 4.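

In this assay compound 4 is reported only as a limit: the limit of > 100000 nM in this assay, at which 1 of the 4 values shown sits.

Methoxy in place of hydrogen on this aromatic carbon gives an at least 6.4-fold higher number from compound 1 to compound 4 (0.80 log units; beyond the scatter), the first reading of this position in the series. Hydrogen in place of methoxy at the same kind of position gives an at least 1.5-fold higher number from compound 2 to compound 4 (0.18 log units; that floor lies within the scatter), so both steps point to a higher number, yet this floor does not by itself separate the two compounds beyond the scatter.

As far as these compounds go, how far compound 4 lies past the limit stays open, and with it the true size of both steps. Also open, from the compounds shown here alone, is how a hydroxyl, a fluorine or an ethoxy on this carbon would read, and whether the methoxy step holds when methoxy replaces the amino group on the ketone-bearing ring.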